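The source may hold more compounds than are shown below. What is called first, only, known or untested is meant among the compounds shown, and "the series" means these compounds.

Compound 1 `CC(=O)ON(/C=C\C(=O)c1ccc(F)cc1)Cc1ccccc1`: > 25000 nM
Compound 2 `O=C(/C=C\N(O)Cc1ccc(-c2ccccc2)cc1)c1ccco1`: 3100 nM

In an assay on RBL-1 cells for inhibition of Polyunsaturated fatty acid 5-lipoxygenase (Rattus norvegicus) (a higher number here means a weaker inhibitor, a lower number a stronger inhibitor), compound 1 stands at a limit, > 25000 nM, which is the limit of > 25000 nM in this assay, at which 1 of the 2 values shown sits. In this assay compound 2 gives 3100 nM, a number rather than a limit. Compound 3 `CC(=O)ON(/C=C\C(=O)c1ccc(Cl)cc1)Cc1ccccc1` differs from compound 1 by chloro in place of fluoro on an aromatic carbon. For the measured compounds named here, no measured pair shows this exchange, so the expected step that the limit leaves unreadable from compound 1 to compound 3 is set at none beyond the scatter. For compound 3 in this assay the estimate is 30000 nM, with a range of 8000 nM to 100000 nM, and another limit is expected to be the likeliest outcome.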

Compound 3, half-maximal inhibitory concentration: > 25000 nM
Compound 3 was reported as a limit (the forecaster's own chance of this, stated with the estimate: 70%); the middle value does not contradict the limit.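

In this assay, compound 1 and compound 3 are both reported only as limits, so no step can be read for chloro in place of fluoro: the limit of > 25000 nM in this assay, at which 2 of the 3 values shown sit. From the compounds shown here alone, whether this exchange changes inhibition at all stays open.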